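Swapping the thiophene amide in a benzothiazole series

This account rests on a few compounds, and the source may have more. Where it says the series, first, only, none or still open, it means among the compounds named here.

Measured so far:
Compound 1, `O=C(CSc1cccc(O)c1)Nc1ccc2nc(NC(=O)c3cc(Cl)cc(Cl)c3)sc2c1`: 5440 nM
Compound 2, `O=C(CSc1cccc(O)c1)Nc1ccc2nc(NC(=O)c3ccc(C(F)(F)F)cc3)sc2c1`: 510 nM
Compound 3, `O=C(CSc1cccc(O)c1)Nc1ccc2nc(NC(=O)c3cccs3)sc2c1`: 7020 nM

All three share one core and differ only in the group attached to the carbonyl carbon of the outer amide. In a functional assay on HCT-116 cells (Homo sapiens) for antiproliferative activity, read by MTT assay, with a stated time of 72 h (on this read-out lower numbers stand for stronger inhibition and higher numbers for weaker inhibition), compound 3 gives the highest number of the three, meaning the weakest inhibition of cell growth; compound 1 sits close to it, since a 1.3-fold higher number from compound 1 to compound 3 (0.11 log units; within the scatter), whereas compound 2 stands far apart, as a 14-fold higher number from compound 2 to compound 3 (1.14 log units; beyond the scatter) shows.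

Compound 4, `O=C(CSc1cccc(O)c1)Nc1ccc2nc(NC(=O)c3ccc(F)cc3)sc2c1`, has not been measured. It differs from compound 3 in one place: 4-fluorophenyl in place of thiophen-2-yl on a carbonyl carbon. The step that bears most on this change is a 14-fold higher number from compound 2 to compound 3 (1.14 log units; beyond the scatter), where a six-membered carbon ring carrying a group in the 4-position was far better than the thiophene. The other large step, an 11-fold lower number from compound 1 to compound 2 (1.03 log units; beyond the scatter), shows that not every six-membered ring gains as much. A lower number is therefore expected for compound 4, with a 3.5-fold lower number from compound 3 to compound 4 (0.55 log units; beyond the scatter) estimated, giving about 2000 nM, within a range of 600 nM to 6000 nM.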

Compound 4, half-maximal inhibitory concentration: 6170 nM
Estimate against measurement, compound 4: 3.1-fold (0.49 log units) below; the measured number lies above the stated range.
By their numbers in this assay, from the lowest: compound 2; then compounds 1, 4 and 3 (each within the scatter of the next).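

In this assay, a six-membered carbon ring does not by itself outdo the thiophene: 4-fluorophenyl in place of thiophen-2-yl gives (a 1.1-fold lower number from compound 3 to compound 4 (0.06 log units; within the scatter)), and the comparison with the 3,5-dichlorophenyl compound gives (a 1.1-fold higher number from compound 1 to compound 4 (0.05 log units; within the scatter)). The outcome depends on the group carried by the ring, as fluoro in place of trifluoromethyl gives (a 12-fold higher number from compound 2 to compound 4 (1.08 log units; beyond the scatter)), which leaves compound 2 as the only one of the four set apart from the others. Nothing measured here accounts for this difference.

On these data alone, it remains open how 4-chlorophenyl or 4-methoxyphenyl on this carbonyl carbon would compare with 4-(trifluoromethyl)phenyl. The shown compounds also leave open whether the result for compound 2 would carry over to a cell line other than HCT-116.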